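The source may report more compounds than this note shows. Statements on the series, on what has been measured and on what is new or still open speak of the compounds shown alone.

In a functional assay on HO8910 cells (Homo sapiens) for inhibition, read by MTT assay, with a stated time of 24 h, tested at 100 ug/mL (on this read-out lower numbers stand for less inhibition of growth and higher numbers for more inhibition of growth at the one concentration tested), compound 1 `O=C(CCCCC1CCSS1)Nc1ccccn1` gives 51.9% and stands lowest of the two measured numbers, while compound 2 `O=C(CCCCC1CCSS1)Nc1ccc(Cl)cn1` gives 68.6% as the higher one. Compound 3 `O=C(CCCCC(S)CCS)Nc1ccccn1` differs from compound 1 by a group of 5 heavy atoms (3 carbon, 2 sulfur; no ring) in place of a group of 5 heavy atoms (3 carbon, 2 sulfur; one five-membered non-aromatic ring with 2 hetero atoms), on a saturated chain carbon, four bonds along the chain from a carbonyl carbon and so has no ring in that group. Among the compounds with values here, the one measured step is a number 16.7 percentage points higher from compound 1 to compound 2 (beyond the scatter) for chloro in place of hydrogen on an aromatic carbon, a different change, so no measured step bears directly on this one. As far as these compounds go, no step beyond the scatter is therefore expected in this assay and the direction stays open. An estimated a number 3.1 percentage points higher from compound 1 to compound 3 (within the scatter) is what this expectation comes to. For compound 3 the estimated value is 55%, with 40% to 72% as its expected range.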

Compound 3, percent growth inhibition at one concentration: 14.2%
Compound 3: the middle estimate sits 40.8 percentage points above what was measured; measured number below the stated range.
By their numbers in this assay, from the lowest: compound 3; then compound 1; then compound 2.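

Replacing the five-membered non-aromatic ring with 1,3-disulfanylpropyl, on a saturated chain carbon, four bonds along the chain from a carbonyl carbon, gives a number 37.7 percentage points lower from compound 1 to compound 3 (beyond the scatter) in this assay. Within the data shown here, the earlier chloro step touched only the aromatic carbon, so this is the first sign that the read-out is sensitive at this chain position, even though the group's heavy atom count stays the same. Nothing available bears on the reason for this loss.

The compounds shown leave open whether the loss goes with the missing ring or with the 2 hydrogen-bond donors that enter. A six-membered ring holding two sulfur atoms, or the open chain with a methyl group on each sulfur, would bear on this.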